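Trading one pyridinyl ether for another: a permeability outlook

The source may hold more compounds than are shown below. What is called first, only, known or untested is meant among the compounds shown, and "the series" means these compounds.

Compound 1: `Cc1ccc(Oc2ccc3nc(COc4cccc(C(=O)O)c4)n(C)c3n2)cc1C` gives 12.4 10^-6 cm/s
Compound 2: `Cn1c(COc2cccc(C(=O)O)c2)nc2ccc(Oc3cccc(Cl)n3)cc21` gives 7.6 10^-6 cm/s

Of the compounds shown here, two have been measured in an ADME assay for permeability, using PAMPA, with a stated time of 4 h; a higher number here means that the compound crosses the layer faster, a lower number that the compound crosses the layer more slowly. Compound 1 gives 12.4 10^-6 cm/s, and compound 2 gives 7.6 10^-6 cm/s. These two numbers lie within the usual scatter of each other, so neither compound can be set apart from the other on this evidence; compound 2 simply holds the smaller of the two figures.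

Compound 3 is `Cc1cc(F)cnc1Oc1ccc2nc(COc3cccc(C(=O)O)c3)n(C)c2c1`, not yet measured in this assay. It differs from compound 2 in one place: 5-fluoro-3-methylpyridin-2-yl in place of 6-chloropyridin-2-yl on an oxygen on an aromatic ring. The leaving and the entering group are each a single six-membered aromatic ring carrying one nitrogen, with one hydrogen-bond acceptor and no donor on either side, and no change in charge.

Going by the values given here, no step of this kind has been measured here. Given how close the two pyridinyl ether analogues already are, only a small step is expected, a 1.1-fold higher number from compound 2 to compound 3 (0.05 log units; within the scatter), in no direction beyond the scatter. Compound 3 is therefore estimated at 8.5 10^-6 cm/s, within a range from 4 10^-6 cm/s to 16 10^-6 cm/s.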

Compound 3, apparent permeability: 8.3 10^-6 cm/s
For compound 3 the middle estimate is 1.0-fold (0.01 log units) above the measured one; the range from low to high includes it.
By their numbers in this assay, from the lowest: compounds 2, 3 and 1 (each within the scatter of the next).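

In this assay, going by these compounds alone, putting 5-fluoro-3-methylpyridin-2-yl in place of 6-chloropyridin-2-yl on an oxygen on an aromatic ring gives a 1.1-fold higher number from compound 2 to compound 3 (0.04 log units; within the scatter) and so offers the first reading of a change at this one place, since compounds 1 and 2 provided no such single-place step. Although this change removes a chlorine, brings in a fluorine and a methyl, and moves from 7 heavy atoms to 8, the two compounds cannot be told apart in this read-out. Both groups remain a six-membered aromatic ring with one nitrogen and no net charge, but nothing measured here explains why the two values fall so close together.

Because the chlorine, fluorine and methyl differences arrive as one package, this single step cannot show what each would do alone, or whether their separate contributions are small or merely offset one another. It also leaves open whether this place stays just as undemanding when the ring on the oxygen carries a very different group, such as an amine or a carboxylic acid.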